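From Chlorophenylsulfanyl to Phenylsulfanyl: an Expected Small Shift

A few compounds are considered here, and "the series" means these few. Any claim that something is new, unique, unknown or untested is made for them only; others in the source may bear on it.

Compound 1 `CCc1cc(C)c(C(=O)N=C(N)N)cc1S(C)(=O)=O`: 4.8 nM
Compound 2 `Cc1cc(Sc2cccc(Cl)c2)c(S(C)(=O)=O)cc1C(=O)N=C(N)N`: 37 nM
Compound 3 `Cc1cc(Sc2ccc(Cl)cc2)c(S(C)(=O)=O)cc1C(=O)N=C(N)N`: 19 nM

Of the compounds shown here, three have been measured in a functional assay for inhibition of sodium/hydrogen exchanger (Oryctolagus cuniculus); on this read-out lower numbers stand for stronger inhibition and higher numbers for weaker inhibition. Compound 1 gives 4.8 nM and stands lowest. Compound 3 stands second highest of the three: its step from compound 1 is a 4.0-fold higher number from compound 1 to compound 3 (0.60 log units; beyond the scatter), and its separation from compound 2 is a 1.9-fold lower number from compound 2 to compound 3 (0.29 log units; within the scatter). Compound 2 itself, reached from compound 1 by a 7.7-fold higher number from compound 1 to compound 2 (0.89 log units; beyond the scatter), sits highest.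

Compound 4 `Cc1cc(Sc2ccccc2)c(S(C)(=O)=O)cc1C(=O)N=C(N)N` has not yet been measured. It differs from compound 3 by hydrogen in place of chloro on an aromatic carbon; the chloro leaves and hydrogen enters on an aromatic carbon of a six-membered aromatic ring of carbon only, para to a large group.

Among the measured compounds shown here, the only step that touches this part of the molecule is a 1.9-fold lower number from compound 2 to compound 3 (0.29 log units; within the scatter), which moves the chloro between two positions without removing it and stays within the scatter. For the measured compounds named here, no measured step removes the chloro outright, so the expectation rests on that single small step. Compound 4 is therefore expected to give a number close to that of compound 3, with a step of about a 1.3-fold higher number from compound 3 to compound 4 (0.12 log units; within the scatter) in this assay, not clearly beyond the scatter in either direction. Compound 4 is estimated at 25 nM, within a range from 10 nM to 60 nM.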

Compound 4, half-maximal inhibitory concentration: 14 nM
Compound 4: the middle estimate sits 1.8-fold (0.25 log units) above what was measured, and the stated range covers the measured number.
By their numbers in this assay, from the lowest: compound 1; then compounds 4, 3 and 2 (each within the scatter of the next, the first and the last beyond it).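

In this assay, among the compounds shown here, the chloro is removed outright for the first time, and in the 4-chlorophenyl compound this gives a step that stays within the scatter (a 1.4-fold lower number from compound 3 to compound 4 (0.13 log units; within the scatter)), so on this read-out the chloro at that place can go without a clear change. The same exchange on the 3-chlorophenyl compound gives a modest step beyond the scatter (a 2.6-fold lower number from compound 2 to compound 4 (0.42 log units; beyond the scatter)), so the two chlorinated compounds do not respond alike to losing the chloro, and only the 3-chlorophenyl compound stands clearly apart from the unsubstituted phenyl. Phenylsulfanyl in place of ethyl still gives a modest step beyond the scatter (a 2.9-fold higher number from compound 1 to compound 4 (0.46 log units; beyond the scatter)), which shows that the gap to compound 1 remains in this set even with no chloro present.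

No available measurement bears on why these numbers fall as they do. From the compounds shown here alone, it remains open whether a methoxy group, an amine or a carboxylic acid on the phenyl ring would shift the number beyond the scatter, and whether an oxygen or a methylene link in place of the sulfur would leave it where it is.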